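Carbamoyl triazole variants on the ether side chain

This account rests on a few compounds, and the source may have more. Where it says the series, first, only, none or still open, it means among the compounds named here.

Among the compounds with values here, compound 2 `CCO/C(O)=C1\C(COCCN2CC(=O)N(C)C2=O)=NC(C)=C(C(=O)OC)C1c1cccc(Cl)c1Cl` gives 5.01 nM in a functional assay (aorta) with Rattus norvegicus as the target (a higher number here means a weaker inhibitor, a lower number a stronger inhibitor), and holds the highest of the two numbers so far; the nearest is compound 1 `CCO/C(O)=C1\C(COCCn2cc(C(N)=O)nn2)=NC(C)=C(C(=O)OC)C1c1cccc(Cl)c1Cl`, which in this assay gives 3.16 nM, the gap being a 1.6-fold higher number from compound 1 to compound 2 (0.20 log units; within the scatter).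

Compound 3 `CCO/C(O)=C1\C(COCCn2nncc2C(N)=O)=NC(C)=C(C(=O)OC)C1c1cccc(Cl)c1Cl` has not yet been measured. The change is 5-carbamoyl-1H-1,2,3-triazol-1-yl in place of 3-methyl-2,4-dioxoimidazolidin-1-yl on a saturated chain carbon, two bonds along the chain from an oxygen on a saturated carbon. Within the data shown here, only one measured step touches this position: a 1.6-fold higher number from compound 1 to compound 2 (0.20 log units; within the scatter), in which a 4-carbamoyl-1H-1,2,3-triazol-1-yl stood where the 3-methyl-2,4-dioxoimidazolidin-1-yl now stands, and it stayed within the scatter. The group entering in compound 3 is again a carbamoyl-bearing 1,2,3-triazol-1-yl, a 5-carbamoyl-1H-1,2,3-triazol-1-yl instead of the 4-carbamoyl-1H-1,2,3-triazol-1-yl of compound 1. Among the measured compounds shown here, no measured step shows what this alteration within the triazole does, so the expectation rests on the closeness of compound 1 and compound 2 alone. In this assay the expected step is a 1.3-fold lower number from compound 2 to compound 3 (0.10 log units; within the scatter), within the scatter. Compound 3 is estimated at 4 nM in this assay, with a range from 1.5 nM to 12 nM.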

Compound 3, half-maximal inhibitory concentration: 15.9 nM
The estimate for compound 3 lay 4.0-fold (0.60 log units) below the measured number, and the stated range ends below it.
By their numbers in this assay, from the lowest: compounds 1 and 2 (each within the scatter of the next); then compound 3.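

In this assay, the position on the saturated chain carbon, two bonds along the chain from an oxygen on a saturated carbon, proves sensitive to the arrangement of the triazole substituent: 5-carbamoyl-1H-1,2,3-triazol-1-yl in place of 4-carbamoyl-1H-1,2,3-triazol-1-yl gives a 5.0-fold higher number from compound 1 to compound 3 (0.70 log units; beyond the scatter) in this comparison of two groups that differ only in where the carbamoyl sits. The replacement of 3-methyl-2,4-dioxoimidazolidin-1-yl by 5-carbamoyl-1H-1,2,3-triazol-1-yl gives a 3.2-fold higher number from compound 2 to compound 3 (0.50 log units; beyond the scatter) and so shows that the closeness of compound 1 and compound 2 does not extend to every carbamoyl triazole at this position. Nothing available accounts for the weaker result of compound 3.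

Still open, on these data alone, is whether the gap between the two triazole groups would persist with a carboxylic acid or a primary amine in place of the carbamoyl. Also open, as far as these compounds go, is how a longer chain between the ether oxygen and the 4-carbamoyl-1H-1,2,3-triazol-1-yl or 5-carbamoyl-1H-1,2,3-triazol-1-yl would read in this assay.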